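The source may report more compounds than this note shows. Statements on the series, on what has been measured and on what is new or still open speak of the compounds shown alone.

Compounds measured in a functional assay on MCF7 cells (Homo sapiens) for antiproliferative activity, read by MTT assay, with a stated time of 72 h; on this read-out lower numbers stand for stronger inhibition and higher numbers for weaker inhibition:
- compound 1 `CCCSc1nc(N/N=C(\C)c2ccccc2O)c2nnn(Cc3ccc(F)cc3)c2n1`: > 64000 nM
- compound 2 `CCCSc1nc(N/N=C(\C)c2ccccc2O)c2nnn(Cc3ccccc3)c2n1`: 11000 nM
- compound 3 `CCCSc1nc(N/N=C(\C)c2ccccc2O)c2nnn(Cc3cccc(Cl)c3)c2n1`: 39900 nM

The value of compound 1 is a limit of this assay, not a number, and the series holds (the limit of > 64000 nM in this assay, at which 1 of the 3 values shown sits). Among the two numbers shown, compound 3 stands at the higher one, with compound 2 nearest; the step of a 3.6-fold higher number from compound 2 to compound 3 (0.56 log units; beyond the scatter) is beyond the scatter. The step of an at least 5.8-fold lower number from compound 1 to compound 2 (0.76 log units; beyond the scatter) is also beyond the scatter, while the step of an at least 1.6-fold lower number from compound 1 to compound 3 (0.20 log units; that floor lies within the scatter) has a floor that lies within it.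

Compound 4 `CCCSc1nc(N/N=C(\C)c2ccccc2O)c2nnn(Cc3ccc(Br)cc3)c2n1` is not yet measured. It differs from compound 3 by 4-bromophenyl in place of 3-chlorophenyl on a saturated chain carbon bound to an aromatic nitrogen. Within the data shown here, the steps that bear on this are the step from compound 1 to compound 3, which leaves a 4-halophenyl for a 3-chlorophenyl and gave at least a small lowering with a floor within the scatter, and the step from compound 2 to compound 3, which shows that a halogen on the phenyl raised the number modestly. Going from a 3-chlorophenyl to a 4-bromophenyl is therefore expected to raise the number in this assay again, likely toward or beyond the limit seen for compound 1. The expected step is a 1.5-fold higher number from compound 3 to compound 4 (0.18 log units; within the scatter). Compound 4 is estimated at 60000 nM, within 25000 nM to 150000 nM.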

Compound 4, half-maximal inhibitory concentration: 15600 nM
Beside the measured number, compound 4's estimate is 3.8-fold (0.59 log units) above it; measured number outside the range, below it.
By their numbers in this assay, from the lowest: compounds 2 and 4 (each within the scatter of the next); then compound 3. At a limit, above all of these: compound 1.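

In this assay, a 2.6-fold lower number from compound 3 to compound 4 (0.41 log units; beyond the scatter), so swapping 3-chlorophenyl for 4-bromophenyl on a saturated chain carbon bound to an aromatic nitrogen does not continue the rise seen with compound 3, and a halogen on this phenyl does not raise the number in every case: a 1.4-fold higher number from compound 2 to compound 4 (0.15 log units; within the scatter), which leaves compound 2 and compound 4 indistinguishable, whereas compound 3 stays apart from compound 2. Among these compounds, the identity of the halogen on the 4-halophenyl also matters, since an at least 4.1-fold lower number from compound 1 to compound 4 (0.61 log units; beyond the scatter), the first comparison with the halogen changed and its printed place kept. The value of compound 1 is a limit of this assay and not a number, so that step gives only a floor: the limit of > 64000 nM in this assay, at which 1 of the 4 values shown sits.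

The compounds shown do not separate the effect of the halogen's identity from that of its place, since the step from compound 3 to compound 4 changes both, and a 4-chlorophenyl or 3-bromophenyl group would divide the two. Also open, from the compounds shown here alone, is how the number responds to a non-halogen group on the phenyl, such as methoxy or an amine, or to a longer chain in place of the saturated chain carbon.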